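This account rests on a few compounds, and the source may have more. Where it says the series, first, only, none or still open, it means among the compounds named here.

In a functional assay on thoracic aorta (Rattus norvegicus, strain Wistar), with a stated time of 15 min; on this read-out lower numbers stand for an effect already at smaller amounts and higher numbers for an effect only at larger amounts of compound:

- compound 1 `CCOc1ccc(F)cc1C(C)NC(=O)NS(=O)(=O)c1ccccc1`: > 300000 nM (a limit)
- compound 2 `COc1ccc(F)cc1C(C)NC(=O)N(C)S(=O)(=O)c1ccccc1`: 10000 nM

Compound 1 gives > 300000 nM, which is a limit of the assay and not a number. Among the measured compounds shown here, compound 2, at 10000 nM, therefore holds the only actual number so far in this assay.

The next compound is compound 3 `COc1ccc(F)cc1C(C)NC(=O)NS(=O)(=O)c1ccccc1`. It differs from compound 2 in one place: hydrogen in place of methyl on an amide-type nitrogen.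

For the measured compounds named here, no measured pair shows this exchange on its own, so any expectation rests on thin ground. The closest guide is compound 1, which also has hydrogen on that nitrogen and reached only its limit of > 300000 nM. A clear move towards larger amounts therefore seems more likely than no change beyond the scatter, and the assay may again report only a limit. The estimated step of a 10-fold higher number from compound 2 to compound 3 (1.00 log units; beyond the scatter) is expected to be large and to point towards a higher number. For compound 3 the expected value is 100000 nM, with an estimated range of 20000 nM to 300000 nM.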

Compound 3, half-maximal effective concentration: > 300000 nM
Compound 3: no number, only a limit; the forecaster's own chance of this, stated with the estimate: 45%; middle value at least 3.0-fold (0.47 log units) from the limit.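

Among the compounds shown here, this is the first measured exchange at this place, the amide-type nitrogen whose other neighbours are the carbonyl carbon and the sulfonyl sulfur. In this assay, putting hydrogen in place of methyl there gives an at least 30-fold higher number from compound 2 to compound 3 (1.47 log units; beyond the scatter), a large change from one atom swap, and its full size stays hidden: for compound 3, > 300000 nM is a limit of the assay and not a number. The other step, hydrogen in place of methyl on a saturated chain carbon bound to an oxygen on an aromatic ring, cannot be read, so this series says nothing yet about that change, as both compounds concerned sit at one limit: the limit of > 300000 nM in this assay, at which 2 of the 3 values shown sit.

The compounds shown leave open whether methyl is special on this nitrogen, or whether an ethyl group or a longer chain there would give a lower or a higher number. They also leave open how the ethyl chain on the oxygen behaves when this nitrogen carries methyl, the one setting in which a number can be read so far.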